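A few compounds are considered here, and "the series" means these few. Any claim that something is new, unique, unknown or untested is made for them only; others in the source may bear on it.

Values measured in a functional assay on HepG2 cells (Homo sapiens) for inhibition, read by fluorescence and resazurin assay, with a stated time of 72 h (a higher number here means a weaker inhibitor, a lower number a stronger inhibitor), for three compounds:

- compound 1 `O=C(Nc1ccccc1)Nc1cccc(Nc2nccc(Nc3ccc4nc[nH]c4c3)n2)c1` gives 11000 nM
- compound 2 `O=C(Nc1ccccc1)Nc1cccc(Nc2nccc(Nc3ccc4cn[nH]c4c3)n2)c1` gives 8200 nM
- compound 3 `Cc1cnc(Nc2cccc(NC(=O)Nc3ccccc3)c2)nc1Nc1ccc2cn[nH]c2c1` gives 3600 nM

Compound 3 holds the lowest of these three numbers, so it is the strongest inhibitor measured so far, and its gaps to the other two are beyond the scatter. Compound 4 `O=C(Nc1ccccc1)Nc1cccc(Nc2ncc([N+](=O)[O-])c(Nc3ccc4cn[nH]c4c3)n2)c1` has not yet been measured. The change from compound 3 to compound 4 is nitro in place of methyl on an aromatic carbon, ortho to a (1H-indazol-6-yl)amino group (nitro in place of methyl on an aromatic carbon).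

Two measured steps can be compared with this change. The more relevant one, at this same carbon, is a 2.3-fold lower number from compound 2 to compound 3 (0.36 log units; beyond the scatter) with methyl in place of hydrogen, and it is modest in size. The other, a 1.3-fold lower number from compound 1 to compound 2 (0.13 log units; within the scatter) at a different part of the molecule, says little here. Among the measured compounds shown here, no measured compound carries nitro, so the data give no firm direction for this swap. A step of modest size at most therefore seems the sensible expectation, with a slight lean towards a higher number. The expected step is a 1.4-fold higher number from compound 3 to compound 4 (0.14 log units; within the scatter) as a working estimate. For compound 4 the expected value is 5000 nM with an estimated range from 1500 nM to 16000 nM as a deliberately wide allowance.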

Compound 4, half-maximal inhibitory concentration: > 25000 nM
Compound 4: only a limit was reported; the forecaster's own chance of this, stated with the estimate: 10%; middle value at least 5.0-fold (0.69 log units) away from the limit.
By their numbers in this assay, from the lowest: compound 3; then compounds 2 and 1 (each within the scatter of the next). At a limit, above all of these: compound 4.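

In this assay compound 4 gives > 25000 nM, which is a limit and not a number. The earlier compounds shown here showed this aromatic carbon, ortho to a (1H-indazol-6-yl)amino group, moving in one direction only, with a 2.3-fold lower number from compound 2 to compound 3 (0.36 log units; beyond the scatter) on going from hydrogen to methyl, whereas nitro moves it the other way and beyond the scatter, with an at least 6.9-fold higher number from compound 3 to compound 4 (0.84 log units; beyond the scatter) against methyl and an at least 3.0-fold higher number from compound 2 to compound 4 (0.48 log units; beyond the scatter) against hydrogen. So the group on this carbon can shift the number both down and up, but the full size of both nitro steps cannot be read from a single bound: the limit of > 25000 nM in this assay, at which 1 of the 4 values shown sits.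

The compounds shown carry only hydrogen, methyl and nitro on this carbon, so they leave open whether the higher number belongs to nitro alone or would also come with other groups, such as an amine, a nitrile or a longer chain. They also leave open whether nitro would give a similar step with the 1H-benzimidazol-6-yl group of compound 1 in place of 1H-indazol-6-yl.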